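The source may report more compounds than this note shows. Statements on the series, on what has been measured and on what is new or still open speak of the compounds shown alone.

Working notes on the series.

Compound 1 `O=C1/C(=C/c2cccnc2)CN(S(=O)(=O)c2ccc(Cl)cc2)C/C1=C\c1ccccc1F` is the reference. In an ADME assay on L02 cells (Homo sapiens) for cytotoxicity, read by MTT assay, with a stated time of 24 h (a lower number here means a stronger inhibitor, a higher number a weaker inhibitor), compound 1 gives > 20000 nM, which is a limit of the assay and not a number (the limit of > 20000 nM in this assay, at which 1 of the 3 values shown sits). Compound 2 `O=C1/C(=C/c2cccnc2)CN(S(=O)(=O)c2ccc(Br)cc2)C/C1=C\c1ccccc1F` differs from compound 1 by bromo in place of chloro on an aromatic carbon; in this assay compound 2 gives 14600 nM, and the step is an at least 1.3-fold lower number from compound 1 to compound 2 (0.13 log units; that floor lies within the scatter). Compound 3 `O=C1/C(=C/c2cccnc2)CN(S(=O)(=O)c2ccc(Cl)cc2)C/C1=C\c1ccccc1C(F)(F)F` gives 11900 nM in this assay, with the step of an at least 1.6-fold lower number from compound 1 to compound 3 (0.22 log units; that floor lies within the scatter). Compound 2 and compound 3 lie within the scatter of each other, so no order between them is drawn.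

Compound 4 `O=C1/C(=C/c2cccnc2)CN(S(=O)(=O)c2ccc(Br)cc2)C/C1=C\c1ccccc1C(F)(F)F` is not yet measured. It differs from compound 3 by bromo in place of chloro on an aromatic carbon, the same change as from compound 1 to compound 2, made here on the core of compound 3; the two cores differ by trifluoromethyl in place of fluoro on an aromatic carbon. The change occurs twice among the compounds shown. The earlier step, an at least 1.3-fold lower number from compound 1 to compound 2 (0.13 log units; that floor lies within the scatter), started from a limit and gives only a floor, so the new step is expected to be small. The expected step is a 1.3-fold lower number from compound 3 to compound 4 (0.10 log units; within the scatter), resting on compound 3 at 11900 nM. Compound 4 is expected at 9500 nM in this assay, between 4500 nM and 19000 nM.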

Compound 4, half-maximal inhibitory concentration: 13300 nM
Estimate against measurement, compound 4: 1.4-fold (0.15 log units) below; the measured number falls inside the stated range.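

In this assay, bromo in place of chloro gives a 1.1-fold higher number from compound 3 to compound 4 (0.05 log units; within the scatter), and trifluoromethyl in place of fluoro gives a 1.1-fold lower number from compound 2 to compound 4 (0.04 log units; within the scatter), so neither change moves the number beyond the scatter on these cores. The data neither show that the bromo change carries from one core to the other nor show that it fails to carry: the same change on two cores in this assay, an at least 1.3-fold lower number (0.13 log units; that floor lies within the scatter) from compound 1 to compound 2 and a 1.1-fold higher number (0.05 log units; within the scatter) from compound 3 to compound 4; the limit leaves it open whether they differ. The same stands for the trifluoromethyl change: the same change on two cores in this assay, an at least 1.6-fold lower number (0.22 log units; that floor lies within the scatter) from compound 1 to compound 3 and a 1.1-fold lower number (0.04 log units; within the scatter) from compound 2 to compound 4; the limit leaves it open whether they differ.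

As far as these compounds go, compound 1 gives > 20000 nM, which is a limit and not a number, and the true size of both earlier steps stays open with it. Also open, from the compounds shown here alone, is how an amine or a carboxylic acid in place of bromo or chloro on the shared core would read in this assay.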